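Aryl exchange at the shared core: compound 3 to compound 4

This account rests on a few compounds, and the source may have more. Where it says the series, first, only, none or still open, it means among the compounds named here.

Of the compounds shown here, three have been measured in an assay on Sf9 cells for inhibition of protein deacetylase HDAC6 (Homo sapiens), read by fluorescence, with a stated time of 40 min, tested at 100 nM; a lower number here means less inhibition, a higher number more inhibition at the concentration tested (going by the name of the read-out). Compound 1 `O=C(NO)c1ccc(NCc2nc(-c3ccc(F)cc3)nn2-c2ccccc2)cc1` gives 70.9%, compound 2 `O=C(NO)c1ccc(NCc2nc(-c3ccc(Cl)c(Cl)c3)nn2-c2ccccc2)cc1` gives 34.5%, and compound 3 `Cc1cccc(-c2nc(CNc3ccc(C(=O)NO)cc3)n(-c3ccccc3)n2)c1` gives 64.1%. On these numbers compound 3 stands second highest of three; its nearest neighbour is compound 1, within the scatter, and its furthest is compound 2, beyond the scatter. The step of a number 36.4 percentage points lower from compound 1 to compound 2 (beyond the scatter) is large, the step of a number 6.8 percentage points lower from compound 1 to compound 3 (within the scatter) lies within the scatter, and the step of a number 29.6 percentage points higher from compound 2 to compound 3 (beyond the scatter) is modest.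

Compound 4 `O=C(NO)c1ccc(NCc2nc(-c3ccsc3)nn2-c2ccccc2)cc1` is not yet measured. Its difference from compound 3 is thiophen-3-yl in place of 3-methylphenyl on an aromatic carbon; the group sits on an aromatic carbon of the shared core, two ring bonds from the ring atom that bears a phenyl group. Among the compounds with values here, no measured step replaces a six-membered ring by a five-membered one, so the steps that bear on it are the three aryl exchanges at this same position: one large, one modest, one within the scatter. The position admits some variation but not all. A step of no more than modest size, downward, is expected for compound 4, namely a number 9.1 percentage points lower from compound 3 to compound 4 (within the scatter). Compound 4 is therefore estimated at 55%, with a range from 30% to 75%.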

Compound 4, a percentage reported as inhibition, at one concentration (the size of the read-out at that concentration, not a potency): 53.4%
The estimate for compound 4 lay 1.6 percentage points above the measured number; measured number inside the range.
By their numbers in this assay, from the lowest: compound 2; then compound 4; then compounds 3 and 1 (each within the scatter of the next).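

In this assay, thiophen-3-yl, the only five-membered ring at this aromatic carbon among the compounds shown, gives a separate middle level: it falls short of 3-methylphenyl (a number 10.7 percentage points lower from compound 3 to compound 4 (beyond the scatter)) and of 4-fluorophenyl (a number 17.5 percentage points lower from compound 1 to compound 4 (beyond the scatter)) but exceeds 3,4-dichlorophenyl (a number 18.9 percentage points higher from compound 2 to compound 4 (beyond the scatter)). Within the data shown here, the position therefore accepts a five-membered aromatic ring with one sulfur atom and keeps a clear part of the inhibition, while the earlier compounds showed only six-membered aryl exchanges. The smaller group brings no gain: with 5 heavy atoms against the 7 of 3-methylphenyl, thiophen-3-yl stands lower, so among these two groups fewer heavy atoms do not go with more inhibition.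

The compounds shown leave open whether thiophen-2-yl, a pyridinyl ring, or a non-aromatic group such as an aminomethyl or a carboxylic acid would be accepted at this carbon, and how the order of the aryl groups would look as potencies rather than as readings at a single concentration. No measurement at hand accounts for the size of these steps.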